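A few compounds are considered here, and "the series" means these few. Any claim that something is new, unique, unknown or untested is made for them only; others in the source may bear on it.

Compound 2, `COc1cc(-c2nn(-c3cccc(NC(=O)Nc4ccc(Cl)c(C(F)(F)F)c4)c3)cc2-c2ccncc2)ccc1Cl`, carries a urea ending in a (4-chloro-3-(trifluoromethyl)phenyl)amino group. In a functional assay on MCF7 cells (Homo sapiens) for inhibition, read by sulforhodamine B assay, with a stated time of 48 h (a lower number here means that less compound is tolerated, a higher number that more compound is tolerated), compound 2 gives > 32500 nM, which is a limit of the assay and not a number. Compound 1, `COc1cc(-c2nn(-c3cccc(NC(=O)c4cccc(C(F)(F)F)c4)c3)cc2-c2ccncc2)ccc1Cl`, bears instead a 3-(trifluoromethyl)phenyl on the carbonyl carbon. In this assay compound 1 gives > 50000 nM, again a limit. The step that the two limits leave unreadable from compound 1 to compound 2 cannot be sized because the limit of > 32500 nM in this assay, at which 1 of the 2 values shown sits, and the limit of > 50000 nM in this assay, at which 1 of the 2 values shown sits, are both limits. Compound 3, `COc1cc(-c2nn(-c3cccc(NC(=O)Nc4ccc(Cl)c(Cl)c4)c3)cc2-c2ccncc2)ccc1Cl`, differs from compound 2 by chloro in place of trifluoromethyl on an aromatic carbon. For the measured compounds named here, no measured step speaks to this exchange, and the single step between measured compounds is unreadable, so nothing beyond the scatter is expected in this assay. The step that the limit leaves unreadable from compound 2 to compound 3 is therefore an estimate of no change. For compound 3 in this assay the expected value is 40000 nM, in a range from 15000 nM to 100000 nM, most likely reported again only as a limit.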

Compound 3, concentration lethal to 50% of the cells: > 50000 nM
Compound 3: no number, only a limit; the forecaster's own chance of this, stated with the estimate: 75%; middle value at least 1.2-fold (0.09 log units) from the limit.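

In this assay compound 3 gives > 50000 nM, again a limit of the assay and not a number. With compound 1 and compound 2 also at limits, no step among these three compounds can be read. The compounds shown leave open whether chloro in place of trifluoromethyl changes the value at all.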